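Tetrazolyl Amide Versus Carboxyalkyl and Thiazolyl Amides

This account rests on a few compounds, and the source may have more. Where it says the series, first, only, none or still open, it means among the compounds named here.

Compound 1 `O=C(Nc1nnn[nH]1)c1cc(=O)c2ccccc2o1`: 100%
Compound 2 `O=C(O)CCNC(=O)c1cc(=O)c2ccccc2o1`: 0%
Compound 3 `O=C(O)CCCNC(=O)c1cc(=O)c2ccccc2o1`: 0%

In a functional assay on the whole organism for inhibition, with Rattus norvegicus as the target, with a stated time of 30 min, at a dose of 1 mg/kg by the intravenous route (a lower number here means less inhibition, a higher number more inhibition at the dose given (going by the name of the read-out)), compound 3 gives 0%, level with compound 2 and together with it the lowest of the three numbers, while compound 1 stands far above it. Compound 4 `O=C(Nc1nccs1)c1cc(=O)c2ccccc2o1` differs from compound 3 in one place: 1,3-thiazol-2-yl in place of 3-carboxypropyl on an amide-type nitrogen. Going by the values given here, the steps that bear on this are a number 100 percentage points lower from compound 1 to compound 3 (beyond the scatter) and a number 100 percentage points lower from compound 1 to compound 2 (beyond the scatter), both very large, showing that the number in this assay is much higher with 1H-tetrazol-5-yl on the amide-type nitrogen and lower with 2-carboxyethyl or 3-carboxypropyl there. Compound 4 carries a five-membered aromatic ring on that nitrogen too, so a large rise is expected, tempered because compound 1 gives 100% with 1H-tetrazol-5-yl and not with 1,3-thiazol-2-yl. The expected step is a number 60 percentage points higher from compound 3 to compound 4 (beyond the scatter). Compound 4 is therefore estimated at 60%, with a range from 15% to 100%.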

Compound 4, a percentage reported as inhibition, in the whole organism at one dose (the size of the read-out at that dose, not a potency): 15%
Compound 4: the middle estimate sits 45 percentage points above what was measured; low and high end bracket the measured number.
By their numbers in this assay, from the lowest: compounds 2 and 3 (each within the scatter of the next); then compound 4; then compound 1.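

In this assay, a five-membered aromatic ring on the amide-type nitrogen does lift the number over the carboxyalkyl chains, with a number 15 percentage points higher from compound 3 to compound 4 (beyond the scatter) and a number 15 percentage points higher from compound 2 to compound 4 (beyond the scatter). That ring alone does not restore the level of the tetrazole, however: 1,3-thiazol-2-yl on the same nitrogen gives a number 85 percentage points lower from compound 1 to compound 4 (beyond the scatter). The identity of the ring therefore counts for more here than the presence of a ring, and nothing measured accounts for the gap. Still open, on these data alone, is how a 1,2,4-triazol-3-yl or an imidazol-2-yl group on that nitrogen would fall within this span. So is whether a carboxylic acid attached to the thiazole ring would move the number.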